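The source may report more compounds than this note shows. Statements on the series, on what has been measured and on what is new or still open speak of the compounds shown alone.

Of the compounds shown here, three built on one shared core have been tested in a functional assay on M14 cells (Homo sapiens) for antiproliferative activity, with a stated time of 72 h; a higher number here means a weaker inhibitor, a lower number a stronger inhibitor. Compound 1 `C=CC[C@H]1C[C@]2([C@H](C)Cc3ccc(OC)c(OC)c3)OCOC2=CC1=O` gives 300 nM. Compound 2 `C=CC[C@H]1C[C@]2([C@H](C)Cc3ccc(OC)cc3)OCOC2=CC1=O` gives 81 nM in this assay. Compound 3 `C=CC[C@H]1C[C@]2([C@@H](C)Cc3ccc(OC)nc3)OCOC2=CC1=O` differs from compound 2 in a way that is not broken down here; in this assay compound 3 gives 180 nM, which against compound 1 lies within the scatter and against compound 2 beyond it. The change from compound 2 to compound 1 is methoxy in place of hydrogen on an aromatic carbon, and it produced a 3.7-fold higher number from compound 2 to compound 1 (0.57 log units; beyond the scatter). Compound 4 `C=CC[C@H]1C[C@]2([C@@H](C)Cc3cnc(OC)c(OC)c3)OCOC2=CC1=O` has not yet been measured in this assay. It differs from compound 3 by methoxy in place of hydrogen on an aromatic carbon. This is the same kind of change as that from compound 2 to compound 1, though here the ring carries one nitrogen and the entering group sits two atoms from the ring nitrogen. If the earlier step carries over, compound 4 is expected to give 600 nM, somewhere between 250 nM and 1500 nM. Compound 4 is thus expected to move by a 3.3-fold higher number from compound 3 to compound 4 (0.52 log units; beyond the scatter), resting on compound 3 at 180 nM and on a 3.7-fold higher number from compound 2 to compound 1 (0.57 log units; beyond the scatter).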

Compound 4, half-maximal inhibitory concentration: > 20000 nM
Compound 4 gave a limit, no number (the forecaster's own chance of this, stated with the estimate: 5%); at least 33-fold (1.52 log units) between middle value and limit.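

In this assay compound 4 gives > 20000 nM, which is a limit of the assay and not a number. From the compounds shown here alone, the same change, methoxy in place of hydrogen on an aromatic carbon, gave a higher number on both cores, but here it came to an at least 110-fold higher number from compound 3 to compound 4 (2.04 log units; beyond the scatter), so the direction carried over from one core to the other while the size did not: the same change on two cores in this assay, a 3.7-fold higher number (0.57 log units; beyond the scatter) from compound 2 to compound 1 and an at least 110-fold higher number (2.04 log units; beyond the scatter) from compound 3 to compound 4, at least 30-fold (1.47 log units) apart, beyond the scatter of two such steps The true size of this step remains unknown, and a single pair on each core does not show what sets the two steps apart.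

The compounds shown leave open whether a smaller or different group in the same place, such as a hydroxyl, a fluorine or an amine, would be tolerated on the core of compound 3. They also leave open whether a second methoxy at another position of that ring would give a similarly large step.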